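Sulfonamide Antiproliferatives: Dimethylphenyl Exchanged for Methylphenyl

The compounds below may be only part of what the source reports. "The series", "measured", "known", "first", "only" and "open" are said of these compounds alone.

Three sulfonamides sharing one core have been measured in a functional assay on M21 cells (Homo sapiens) for antiproliferative activity, read by sulforhodamine B assay, with a stated time of 48 h; on this read-out higher numbers stand for weaker inhibition and lower numbers for stronger inhibition. Compound 1 `O=C1NCCN1c1ccc(S(=O)(=O)Nc2ccc(I)cc2)cc1` gives 260 nM, compound 2 `O=C1NCCN1c1ccc(S(=O)(=O)Nc2ccc(Br)cc2)cc1` gives 130 nM, and compound 3 `Cc1cccc(NS(=O)(=O)c2ccc(N3CCNC3=O)cc2)c1C` gives 110 nM. For the measured compounds named here, compound 3 holds the lowest of the three numbers, but its gap to compound 2 is within the scatter, so the two cannot be separated; only the step of a 2.4-fold lower number from compound 1 to compound 3 (0.37 log units; beyond the scatter) is beyond the scatter, and even that is modest. The step of a 2.0-fold lower number from compound 1 to compound 2 (0.30 log units; within the scatter) is within the scatter.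

Compound 4 `Cc1ccc(NS(=O)(=O)c2ccc(N3CCNC3=O)cc2)cc1` is not yet measured. It differs from compound 3 in one place: 4-methylphenyl in place of 2,3-dimethylphenyl on a sulfonamide nitrogen. Going by the values given here, no measured pair makes exactly this swap. Among the compounds with values here, the steps that bear on it are the two in which the group on the sulfonamide nitrogen was exchanged: a 2.4-fold lower number from compound 1 to compound 3 (0.37 log units; beyond the scatter) and a 1.2-fold lower number from compound 2 to compound 3 (0.07 log units; within the scatter). Across them, three different groups on that nitrogen gave numbers spread over a modest range, with the 2,3-dimethylphenyl of compound 3 at the low end. Putting 4-methylphenyl in its place is therefore expected to give a small step toward higher numbers, a 1.4-fold higher number from compound 3 to compound 4 (0.13 log units; within the scatter), probably within the scatter. Compound 4 is expected to show 150 nM in this assay, in a range from 60 nM to 400 nM.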

Compound 4, half-maximal inhibitory concentration: 260 nM
Estimate against measurement, compound 4: 1.7-fold (0.24 log units) below; measured number inside the range.
By their numbers in this assay, from the lowest: compounds 3, 2, 1 and 4 (each within the scatter of the next, the first and the last beyond it).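

In this assay, the group on the sulfonamide nitrogen now shows a step that can be read starting from compound 3: going from 2,3-dimethylphenyl, with 8 heavy atoms, to 4-methylphenyl, with 7, gives a 2.4-fold higher number from compound 3 to compound 4 (0.37 log units; beyond the scatter), which is modest but beyond the scatter. Methyl in place of bromo gives a 2.0-fold higher number from compound 2 to compound 4 (0.30 log units; within the scatter), and methyl in place of iodo gives no change at the digits printed from compound 1 to compound 4 (within the scatter), so on these numbers methyl, bromo and iodo on that aromatic carbon cannot be told apart. The 2,3-dimethylphenyl group therefore separates from two of the other groups, those of compound 1 and compound 4, while compound 2 stays within the scatter of compound 3, so any advantage for this group is small and incomplete.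

Nothing available explains why removing one carbon and moving the methyl group changes the number. Still open, going by these compounds, is whether 2-methylphenyl or 3-methylphenyl would stay near compound 3 or near compound 4, and where a phenyl ring carrying a methoxy group, an amine or a carboxylic acid would fall.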